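A few compounds are considered here, and "the series" means these few. Any claim that something is new, unique, unknown or untested is made for them only; others in the source may bear on it.

Among the measured compounds shown here, of the two compounds measured so far, compound 2 `CC(C)CCc1cnc(CCc2ccc(-c3ccccc3C(=O)O)cc2)[nH]1` stands lowest: in an in vitro functional assay on cells for agonist activity at Bombesin receptor subtype-3 (Homo sapiens), read by luminescence and calcium flux (on this read-out higher numbers stand for an effect only at larger amounts of compound and lower numbers for an effect already at smaller amounts), compound 2 gives 119 nM, while compound 1 `N#Cc1cccc(Cc2cnc(CCc3ccc(-c4ccccc4C(=O)O)cc3)[nH]2)c1` gives 812 nM. For the measured compounds named here, the one step available, a 6.8-fold lower number from compound 1 to compound 2 (0.83 log units; beyond the scatter), shows that the group on the saturated chain carbon bound to an aromatic carbon matters, and that a small branched chain there does better than the 3-cyanophenyl ring.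

Compound 3 `O=C(O)c1ccccc1-c1ccc(CCc2ncc(CC3CC3)[nH]2)cc1` carries a further change at that same spot: cyclopropyl in place of isobutyl on a saturated chain carbon bound to an aromatic carbon. Going by the values given here, no measured step trades one small non-aromatic group for another, so the step from compound 1 to compound 2 is the only guide, and it speaks of moderate sensitivity at this place rather than of any direction for losing one carbon and closing a ring. For compound 3 a step near the scatter, if anything towards a somewhat higher number, is expected in this assay, amounting to a 1.7-fold higher number from compound 2 to compound 3 (0.23 log units; within the scatter). The estimate for compound 3 is therefore 200 nM, with a likely range from 70 nM to 600 nM.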

Compound 3, half-maximal effective concentration: 1000 nM
Beside the measured number, compound 3's estimate is 5.0-fold (0.70 log units) below it, and the stated range ends below it.
By their numbers in this assay, from the lowest: compound 2; then compounds 1 and 3 (each within the scatter of the next).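

In this assay the change of isobutyl to cyclopropyl gives an 8.4-fold higher number from compound 2 to compound 3 (0.92 log units; beyond the scatter), so this position separates even two small all-carbon groups, one an open chain and the other a three-membered ring. With cyclopropyl in place of 3-cyanophenyl there is a 1.2-fold higher number from compound 1 to compound 3 (0.09 log units; within the scatter), which shows that a small non-aromatic group does not by itself give a lower number; of the three groups, only the isobutyl of compound 2 stands apart. Nothing available here accounts for the difference between isobutyl and cyclopropyl.

On these data alone, it remains open whether the lower number depends on the branching, on the chain length or on the absence of a ring. An unbranched butyl chain and a cyclobutyl ring at this place would help separate these possibilities.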